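The source may report more compounds than this note shows. Statements on the series, on what has been measured and on what is new or still open speak of the compounds shown alone.

Compound 1 `CC1CCN(c2nc(C(F)(F)F)ccc2CNC(=O)C(c2ccccc2)c2ccc(NS(C)(=O)=O)c(F)c2)CC1` is the stronger of the two compounds measured in an assay on CHO cells for antagonist activity at transient receptor potential cation channel subfamily V member 1 (Homo sapiens), read by FLIPR (a higher number here means a weaker inhibitor, a lower number a stronger inhibitor), where compound 1 gives 1.3 nM. Compound 2 `Cc1ccc(C(C(=O)NCc2ccc(C(F)(F)F)nc2SC2CCCCC2)c2ccc(NS(C)(=O)=O)c(F)c2)cc1` is the other measured compound; in this assay compound 2 gives 7.5 nM, a weaker result that lies beyond the usual scatter of the measurement. The unmeasured compound 3 `Cc1ccc(CC(C(=O)NCc2ccc(C(F)(F)F)nc2N2CCC(C)CC2)c2ccc(NS(C)(=O)=O)c(F)c2)cc1` keeps the core of compound 1 and differs from it in one place: 4-methylbenzyl in place of phenyl on a saturated chain carbon bound to an aromatic carbon and a carbonyl carbon. Within the data shown here, no pair of measured compounds shows this change on its own, so nothing measured here tells how it plays out. Since the change is larger than a simple swap of one aromatic ring for another, a step beyond the scatter toward a weaker inhibitor is expected, estimated as a 6.2-fold higher number from compound 1 to compound 3 (0.79 log units; beyond the scatter). Compound 3 is therefore expected to give about 8 nM in this assay, within a range from 2 nM to 40 nM.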

Compound 3, inhibition constant: "active" (no number reported)
Nothing numeric was reported for compound 3, and the estimate cannot be compared.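

In this assay, among these compounds, compound 3 is reported only as active, without a number, so no step from compound 1 to compound 3 can be read. How far 4-methylbenzyl in place of phenyl shifts the inhibition constant stays open, and no evidence shown bears on this result.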